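The compounds below may be only part of what the source reports. "The series", "measured", "known", "first", "only" and "open" are said of these compounds alone.

Compound 1 `Cc1ccc2c(=O)c(CSC(=S)N(C(C)C)C(C)C)coc2c1` and compound 3 `Cc1ccc2c(=O)c(CSC(=S)N3CCOCC3)coc2c1` share one core; compound 2 `CC(C)N(C(=S)SCc1cc(=O)c2ccccc2o1)C(C)C` and the still unmeasured compound 4 `O=c1cc(CSC(=S)N2CCOCC2)oc2ccccc12` share another, and the difference between the two cores is not broken down here. In a functional assay on LM7 cells (Homo sapiens) for antiproliferative activity, read by MTT assay, with a stated time of 72 h (a higher number here means a weaker inhibitor, a lower number a stronger inhibitor), compound 1 gives 6300 nM and compound 3 gives 14300 nM. The change morpholin-4-yl in place of diisopropylamino on a thiocarbonyl carbon produced a 2.3-fold higher number from compound 1 to compound 3 (0.36 log units; beyond the scatter). Compound 2 in this assay reaches only the limit > 25000 nM, not a number. The same change, (morpholin-4-yl in place of diisopropylamino on a thiocarbonyl carbon), is now applied to compound 2. Since compound 2 already sits at the limit of > 25000 nM in this assay, at which 1 of the 3 values shown sits, and the earlier step ran toward weaker inhibition, compound 4 is expected to remain at or past that limit. The step that the limit leaves unreadable from compound 2 to compound 4 is expected to match the earlier one in direction, with no number likely reported. Compound 4 is estimated at 60000 nM, within a range from 25000 nM to 200000 nM.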

Compound 4, half-maximal inhibitory concentration: 25200 nM
Compound 4: middle estimate off by 2.4-fold (0.38 log units), on the high side, and the stated range covers the measured number.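

No step can be read from compound 2 to compound 4, because the value of compound 2 is a limit and not a number: the limit of > 25000 nM in this assay, at which 1 of the 4 values shown sits.

Left open is whether morpholin-4-yl in place of diisopropylamino shifts the number on the core of compound 2 as it does on the core of compound 1.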